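Removing the pentyl chain from compound 1

This account rests on a few compounds, and the source may have more. Where it says the series, first, only, none or still open, it means among the compounds named here.

Compound 1 `CCCCCc1cc2nn(-c3ccccc3)cc2c(C)n1` is the point of departure. In a functional assay on K562 cells (Homo sapiens) for inhibition, read by fluorescence, with a stated time of 72 h (on this read-out lower numbers stand for stronger inhibition of growth and higher numbers for weaker inhibition of growth), compound 1 gives 6900 nM, the lowest of the two plain numbers in the set, though compound 2 `c1ccc(-n2cc3cnc(-c4ccsc4)cc3n2)cc1` with 8300 nM stands within the scatter of it, so the two cannot be ordered. Going by these compounds, compound 3 `Cc1nc(CCO)cc2nn(-c3ccccc3)cc12` gives only a limit, > 100000 nM, so its true number is unknown. The step of an at least 14-fold higher number from compound 1 to compound 3 (1.16 log units; beyond the scatter) nonetheless shows that altering the pentyl chain cost compound 1 a large share of its activity, the reading of compound 3 sitting at the limit of > 100000 nM in this assay, at which 1 of the 3 values shown sits.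

Compound 4 `Cc1nccc2nn(-c3ccccc3)cc12` differs from compound 1 in one place: hydrogen in place of pentyl on an aromatic carbon. This removes the whole chain from the aromatic carbon of the six-membered aromatic ring with 1 nitrogen. Among the measured compounds shown here, the one measured step that touches this chain was large and in the weakening direction, and compound 4 is expected to move the same way, with an estimated step of a 10-fold higher number from compound 1 to compound 4 (1.01 log units; beyond the scatter). Compound 4 is thus estimated at 70000 nM, within a range of 20000 nM to 300000 nM, with a real chance that only a limit is reported.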

Compound 4, concentration for 50% growth inhibition: > 100000 nM
Compound 4 gave a limit, no number; the forecaster's own chance of this, stated with the estimate: 45%; middle value at least 1.4-fold (0.15 log units) away from the limit.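

The step of an at least 14-fold higher number from compound 1 to compound 4 (1.16 log units; beyond the scatter) shows that the shared core, with only hydrogen on this aromatic carbon next to the ring nitrogen, does not keep the growth inhibition of compound 1 in this assay. Compound 3 showed the cost of replacing the pentyl chain with a hydroxy-bearing chain, whereas compound 4 shows the same kind of loss with no chain at all. Compound 4 gives only a limit, as compound 3 does: the limit of > 100000 nM in this assay, at which 2 of the 4 values shown sit.

The step from compound 3 to compound 4 cannot be read, so 2-hydroxyethyl and hydrogen cannot be ordered at this position. Also open, going by these compounds, is how much of the pentyl chain is needed, and whether a propyl chain, a longer chain or an amine on this carbon would match compound 1.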